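The source may report more compounds than this note shows. Statements on the series, on what has been measured and on what is new or still open speak of the compounds shown alone.

Measured compounds in a functional assay on Hs-578T cells (Homo sapiens) for inhibition, read by sulforhodamine B assay, with a stated time of 48 h; on this read-out higher numbers stand for weaker inhibition of growth and lower numbers for stronger inhibition of growth:
- compound 1, `Nc1cc(N)c2nc(-c3ccccc3)c(Sc3ccc(F)cc3)nc2c1`: 61700 nM
- compound 2, `COc1ccc(CNc2nc3cc(N)cc(N)c3nc2-c2ccccc2)cc1OC`: a limit of the assay, < 100000 nM
- compound 3, `COc1ccc(CNc2nc3cc(N)cc(N)c3nc2-c2ccccc2)cc1`: a limit of the assay, < 100000 nM

For the measured compounds named here, compound 1 is the only member of the set with an actual number in this assay; the other two values are limits. Going by the values given here, the step from compound 2 to compound 3 is a step that the two limits leave unreadable from compound 2 to compound 3, so it shows nothing about the effect of removing a methoxy group here, and it is the only measured step in the set. The limit of < 100000 nM in this assay, at which 2 of the 3 values shown sit, is the one recurring feature of the measured data.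

Compound 4, `COc1ccc(Sc2nc3cc(N)cc(N)c3nc2-c2ccccc2)cc1`, is compound 1 with methoxy in place of fluoro on an aromatic carbon. Among the compounds with values here, no measured pair shares this change: the only pair with a methoxy involved gives an unreadable step, and neither limit can be turned into a number. In the absence of any readable step, the expectation for compound 4 is a value near that of compound 1, with no change beyond the scatter, giving an estimated step of a 1.0-fold lower number from compound 1 to compound 4 (0.01 log units; within the scatter). Compound 4 is therefore estimated at 60000 nM, within a range from 25000 nM to 100000 nM in this assay.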

Compound 4, concentration for total growth inhibition: < 100000 nM
Compound 4 ended at the assay's limit; the forecaster's own chance of this, stated with the estimate: 35%; the middle value is on the limit's open side.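

In this assay compound 4 gives < 100000 nM, a limit of the assay and not a number, so no new step can be read between compound 1 and compound 4. The compounds shown leave open what size of effect, if any, methoxy in place of fluoro has on the shared core, with most values resting on one limit: the limit of < 100000 nM in this assay, at which 3 of the 4 values shown sit.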